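This account rests on a few compounds, and the source may have more. Where it says the series, first, only, none or still open, it means among the compounds named here.

Measured compounds:
Compound 1 `CCOC(=O)c1ccc(SCc2ccc3nc(OC)c(OC)nc3c2)cc1`: in an ADME assay on BHK-21 cells (Mesocricetus auratus) for cytotoxicity, read by MTT assay, with a stated time of 96 h (on this read-out lower numbers stand for higher toxicity in this test and higher numbers for lower toxicity in this test), compound 1 gives > 100000 nM, which is a limit of the assay and not a number.
Compound 2 `COc1nc2ccc(CSc3ccc(C(=O)O)cc3)cc2nc1OC`: in this assay compound 2 gives 65000 nM.
Compound 3 `CCOC(=O)c1ccc(SCc2ccc3nc(OC)c(OC)nc3c2)nc1`: in this assay compound 3 gives > 100000 nM, again a limit of the assay and not a number.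

One step is measured within the set, from compound 1 to compound 2: hydrogen in place of ethyl on an oxygen next to a carbonyl group. In this assay it reads an at least 1.5-fold lower number from compound 1 to compound 2 (0.18 log units; that floor lies within the scatter). As the starting value is a limit, only a floor for this step is known, and that floor lies within the scatter, so no order between the two compounds can be stated. the limit of > 100000 nM in this assay, at which 2 of the 3 values shown sit, marks where the two limited values sit.

Compound 4 `COc1nc2ccc(CSc3ccc(C(=O)O)cn3)cc2nc1OC` is not yet measured. It stands to compound 3 as compound 2 stands to compound 1: hydrogen in place of ethyl on an oxygen next to a carbonyl group. The place of the change is worded identically in both pairs, so it is the same change. How the core of compound 3 differs from the core of compound 1 is not broken down here.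

For compound 4 in this assay the expected step is an at least 1.2-fold lower number from compound 3 to compound 4 (0.09 log units; that floor lies within the scatter), set beside an at least 1.5-fold lower number from compound 1 to compound 2 (0.18 log units; that floor lies within the scatter), and it rests on that earlier step being only a floor within the scatter and on compound 3 giving > 100000 nM. Compound 4 is therefore estimated at 80000 nM, between 40000 nM and 200000 nM, with a real chance that only a limit is reported.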

Compound 4, half-maximal cytotoxic concentration: > 100000 nM
Compound 4 was reported as a limit (the forecaster's own chance of this, stated with the estimate: 50%); at least 1.2-fold (0.09 log units) between middle value and limit.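

No step can be read from compound 3 to compound 4 in this assay, since the two values are both limits of the assay and not numbers: the limit of > 100000 nM in this assay, at which 3 of the 4 values shown sit.

The compounds shown leave open whether hydrogen in place of ethyl on an oxygen next to a carbonyl group changes the read-out at all on the core of compound 3, and whether compound 1 and compound 2 differ beyond the scatter.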